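Swapping the acetamidophenyl group for a chloropyridinyl ring

The compounds below may be only part of what the source reports. "The series", "measured", "known", "first", "only" and "open" are said of these compounds alone.

Of the compounds shown here, three sharing one core have been tested in a functional assay on NCI-H322 cells (Homo sapiens) for cytotoxicity, read by MTT assay, with a stated time of 24 h; a lower number here means a stronger inhibitor, a higher number a weaker inhibitor. Compound 1 `COc1ccc(/C=C\C(=O)O)c(OCc2cn(-c3ccc(NC(C)=O)cc3)nn2)c1CC=C(C)C` gives 45700 nM, the highest number of the three. Compound 2 `COc1ccc(/C=C\C(=O)O)c(OCc2cn(-c3ccccc3I)nn2)c1CC=C(C)C` gives 42300 nM, and compound 3 `COc1ccc(/C=C\C(=O)O)c(OCc2cn(-c3ccc(C#N)cc3)nn2)c1CC=C(C)C` gives 18600 nM. The change a 1.1-fold lower number from compound 1 to compound 2 (0.03 log units; within the scatter) stayed within the scatter, while a 2.5-fold lower number from compound 1 to compound 3 (0.39 log units; beyond the scatter) and a 2.3-fold lower number from compound 2 to compound 3 (0.36 log units; beyond the scatter) were modest gains. Compound 4 `COc1ccc(/C=C\C(=O)O)c(OCc2cn(-c3cccnc3Cl)nn2)c1CC=C(C)C` differs from compound 1 as follows: 2-chloropyridin-3-yl in place of 4-acetamidophenyl on an aromatic nitrogen. Among the compounds with values here, the nearest precedent is the replacement of 4-acetamidophenyl by 2-iodophenyl, which moved nothing beyond the scatter, so for compound 4 only a small step is expected, a 1.2-fold lower number from compound 1 to compound 4 (0.08 log units; within the scatter), in this assay. Compound 4 is therefore estimated at 38000 nM, with a range from 18000 nM to 80000 nM.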

Compound 4, half-maximal inhibitory concentration: 42200 nM
Compound 4: the middle estimate sits 1.1-fold (0.05 log units) below what was measured; low and high end bracket the measured number.
By their numbers in this assay, from the lowest: compound 3; then compounds 4, 2 and 1 (each within the scatter of the next).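

The 2-chloropyridin-3-yl group, which brings a ring nitrogen and a chlorine and has no hydrogen-bond donor, stands level with both the 4-acetamidophenyl group, a 1.1-fold lower number from compound 1 to compound 4 (0.03 log units; within the scatter), and the 2-iodophenyl group, a 1.0-fold lower number from compound 2 to compound 4 (0.00 log units; within the scatter). The gap to the 4-cyanophenyl group remains, a 2.3-fold higher number from compound 3 to compound 4 (0.36 log units; beyond the scatter), so among these compounds only compound 3 stands apart. Nothing measured here bears on this result. From the compounds shown here alone, it remains open whether a nitrile on the pyridine ring would match compound 3, and how an amine or a methoxy group on the aromatic ring would read.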